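The source may hold more compounds than are shown below. What is called first, only, known or untested is meant among the compounds shown, and "the series" means these compounds.

Compound 3 `CCc1cc(C#N)ccc1C/N=c1\c(O)c(O)\c1=N/C(C)(C)CC` gives 110 nM in a functional assay for inhibition, with Rattus norvegicus as the target (on this read-out higher numbers stand for weaker inhibition and lower numbers for stronger inhibition), while compound 1 `CCc1cc(C#N)ccc1C/N=c1\c(O)c(O)\c1=N/C(C)(C)C` gives 240 nM in this assay. The step between them is a 2.2-fold higher number from compound 3 to compound 1 (0.34 log units; beyond the scatter), and the structural change behind it is hydrogen in place of methyl on a saturated chain carbon, two bonds along the chain from a double-bonded nitrogen. Compound 2 `CC[C@@H](C)/N=c1\c(O)c(O)\c1=N/Cc1ccc(C#N)cc1` carries a different partner on the shared core, and in this assay compound 2 gives 4000 nM, the highest of the three numbers. The difference between the cores of compound 2 and compound 3 is not broken down here. Compound 4 `CCC/N=c1\c(O)c(O)\c1=N/Cc1ccc(C#N)cc1` derives from compound 2 by hydrogen in place of methyl on a saturated chain carbon bound to a double-bonded nitrogen and a saturated chain carbon. This is the same kind of change as from compound 3 to compound 1, though the place differs: there the carbon sits two bonds along the chain from a double-bonded nitrogen, here it is bound to a double-bonded nitrogen and a saturated chain carbon. Because a 2.2-fold higher number from compound 3 to compound 1 (0.34 log units; beyond the scatter) was modest, a step of a 1.8-fold higher number from compound 2 to compound 4 (0.24 log units; within the scatter) is expected for compound 4. Compound 4 is therefore estimated at 7000 nM, with a range from 2500 nM to 20000 nM.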

Compound 4, half-maximal inhibitory concentration: 21900 nM
Estimate against measurement, compound 4: 3.1-fold (0.50 log units) below, outside the stated range (above it).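

In this assay the same change, hydrogen in place of methyl, gives a 5.5-fold higher number from compound 2 to compound 4 (0.74 log units; beyond the scatter), which points the same way as the earlier step, and the two steps do not differ beyond the scatter: the same change on two cores in this assay, a 2.2-fold higher number (0.34 log units; beyond the scatter) from compound 3 to compound 1 and a 5.5-fold higher number (0.74 log units; beyond the scatter) from compound 2 to compound 4, 2.5-fold (0.40 log units) apart, within the scatter of two such steps. Within this series, the direction of the change therefore carried from one core to the other, and the two sizes cannot be told apart. Within the data shown here, with only two pairs, this does not show that the change would behave alike on any further core, nor does it explain why the number rises.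

From the compounds shown here alone, it remains open how a longer chain at this place would read out. Going by these compounds, whether an amine or a carboxylic acid on that chain would fit the same trend also remains open.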